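The source may report more compounds than this note shows. Statements on the series, on what has been measured and on what is new or still open speak of the compounds shown alone.

In a functional assay on QG-56 cells (Homo sapiens) for antiproliferative activity (a lower number here means a stronger inhibitor, a higher number a weaker inhibitor), compound 2 `Cn1cncc1C(O)(c1ccc(C#N)cc1)c1cc2cc([N+](=O)[O-])cc(-c3ccc(C#N)cc3)c2o1` gives 32.6 nM, which lies within the scatter of compound 1 `COc1cccc(-c2cc([N+](=O)[O-])cc3cc(C(O)(c4ccc(C#N)cc4)c4cncn4C)oc23)c1` at 38.8 nM. Compound 3 `COc1cccc(-c2cc(CN(C)C)cc3cc(C(O)(c4ccc(C#N)cc4)c4cncn4C)oc23)c1` gives 142 nM, a higher number than either. Compound 4 `COc1ccc(-c2cc([N+](=O)[O-])cc3cc(C(O)(c4ccc(C#N)cc4)c4cncn4C)oc23)cc1` departs from compound 2 by methoxy in place of cyano on an aromatic carbon, para to a large group: methoxy in place of cyano on an aromatic carbon. The closest evidence is the exchange of a methoxy-bearing aryl group for 4-cyanophenyl, a 1.2-fold lower number from compound 1 to compound 2 (0.08 log units; within the scatter). Among the compounds with values here, no measured compound carries methoxy at the place it occupies in compound 4, so this comparison is only indirect. The other measured change, a 3.7-fold higher number from compound 1 to compound 3 (0.56 log units; beyond the scatter), replaces nitro, a group that compound 2 and compound 4 both keep, so it bears little on this step. With only the small step from compound 1 as a guide, no shift beyond the scatter is expected in this assay. The expected step is a 1.2-fold higher number from compound 2 to compound 4 (0.09 log units; within the scatter). For compound 4 the estimated value is 40 nM, with an expected range of 16 nM to 100 nM.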

Compound 4, half-maximal inhibitory concentration: 36 nM
Beside the measured number, compound 4's estimate is 1.1-fold (0.05 log units) above it; the range from low to high includes it.
By their numbers in this assay, from the lowest: compounds 2, 4 and 1 (each within the scatter of the next); then compound 3.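

The exchange of 4-cyanophenyl for 4-methoxyphenyl can now be read directly in this assay as a 1.1-fold higher number from compound 2 to compound 4 (0.04 log units; within the scatter) and shows that methoxy and cyano, on this aromatic carbon para to a large group, cannot be told apart here. Moving the methoxy group, with 4-methoxyphenyl in place of 3-methoxyphenyl, gives a 1.1-fold lower number from compound 1 to compound 4 (0.03 log units; within the scatter) and so also stays within the scatter, which means that the three aryl groups compared on this nitro-bearing core show no separation in this assay. No evidence is available that bears on this result.

As far as these compounds go, whether an amine or a carboxylic acid on this phenyl ring would also leave the number within the scatter remains open. From the compounds shown here alone, it is also open whether (dimethylamino)methyl in place of nitro would give the same step alongside 4-cyanophenyl or 4-methoxyphenyl as it does alongside 3-methoxyphenyl.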